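Nitro for methoxy on a weakly cytotoxic coumarin ether

A few compounds are considered here, and "the series" means these few. Any claim that something is new, unique, unknown or untested is made for them only; others in the source may bear on it.

Measured compounds:
- Compound 1, `O=c1ccc2cc(OCc3cc(-c4ccccc4[N+](=O)[O-])no3)ccc2o1`: "not determined" (no result reported) in a functional assay on COLO 205 cells (Homo sapiens) for cytotoxicity, read by MTT assay, with a stated time of 48 h; on this read-out lower numbers stand for stronger inhibition and higher numbers for weaker inhibition
- Compound 2, `COc1ccc(-n2cc(COc3ccc4oc(=O)ccc4c3)nn2)cc1`: 32800 nM

Among the measured compounds shown here, compound 2 is the only compound in this set with a number behind it; compound 1 carries "not determined" (no result reported), so nothing can be said about how the two compare. In this assay compound 2 gives 32800 nM, which is a weak effect.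

Compound 3, `O=c1ccc2cc(OCc3cn(-c4ccc([N+](=O)[O-])cc4)nn3)ccc2o1`, keeps the shared core and the linker of compound 2 and changes one group: nitro in place of methoxy on an aromatic carbon. The change sits on an aromatic carbon of a six-membered aromatic ring of carbon only, para to a large group, so the rest of the molecule is untouched.

For the measured compounds named here, no pair of measured compounds shows this or any other single change, so there is no measured step to lean on. The expectation is therefore a small step, in either direction, of a size that would not clearly exceed the usual scatter, and compound 3 is estimated at 25000 nM, within 8000 nM to 80000 nM, which means an expected step of a 1.3-fold lower number from compound 2 to compound 3 (0.12 log units; within the scatter).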

Compound 3, half-maximal inhibitory concentration: 48700 nM
The estimate for compound 3 lay 1.9-fold (0.29 log units) below the measured number; the range from low to high includes it.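

In this assay, among the compounds shown here, the exchange of nitro for methoxy on this aromatic carbon, para to a large group, gives a 1.5-fold higher number from compound 2 to compound 3 (0.17 log units; within the scatter) and is the first measured step at this position. Going from 4-methoxyphenyl to 4-nitrophenyl therefore makes no difference that can be told apart from the ordinary spread of repeated measurements, so this single swap gives no sign that the position controls the cytotoxic effect in either direction. No accompanying measurement bears on this result, so it stays a plain observation with no explanation attached.

On these data alone, a single step between two groups says little about the position as a whole, and it remains open whether a different group on the same aromatic carbon, such as an amine or a carboxylic acid, would shift the number beyond that spread. Compound 1 carries no number, so it adds nothing to this picture, and whether any change elsewhere in these molecules matters more than this one also remains unanswered.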